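A few compounds are considered here, and "the series" means these few. Any claim that something is new, unique, unknown or untested is made for them only; others in the source may bear on it.

Measured compounds:
compound 1 `CCO/C(O)=C1\C(COCCNC(C)=O)=NC(C)=C(C(=O)OC)C1c1ccccc1Cl`, in a functional assay (aorta) with Rattus norvegicus as the target (a lower number here means a stronger inhibitor, a higher number a weaker inhibitor), compound 1 gives 15.9 nM.
compound 2 `CCO/C(O)=C1\C(COCCNC(=O)c2cnccn2)=NC(C)=C(C(=O)OC)C1c1ccccc1Cl`, in this assay compound 2 gives 39.8 nM.

Compound 1 stands lowest of the two numbers; the step to compound 2 is a 2.5-fold higher number from compound 1 to compound 2 (0.40 log units; beyond the scatter), a pyrazin-2-yl in place of methyl on a carbonyl carbon.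

Compound 3 `CCO/C(O)=C1\C(COCCNC(=O)NC)=NC(C)=C(C(=O)OC)C1c1ccccc1Cl` is not yet measured. It differs from compound 1 thus: methylamino in place of methyl on a carbonyl carbon. Among the compounds with values here, the only step that bears on it is the change on the same carbonyl carbon, a 2.5-fold higher number from compound 1 to compound 2 (0.40 log units; beyond the scatter), which was modest. Methylamino is a smaller change than pyrazin-2-yl there, so a step within the scatter or a small rise in this assay is expected for compound 3: a 1.4-fold higher number from compound 1 to compound 3 (0.14 log units; within the scatter). Compound 3 is estimated at 22 nM, range 9 nM to 60 nM.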

Compound 3, half-maximal inhibitory concentration: 3.16 nM
Estimate against measurement, compound 3: 7.0-fold (0.84 log units) above, outside the stated range (below it).
By their numbers in this assay, from the lowest: compound 3; then compound 1; then compound 2.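

At this carbonyl carbon the substituent can move the number in either direction in this assay: methylamino in place of methyl gives a 5.0-fold lower number from compound 1 to compound 3 (0.70 log units; beyond the scatter), opposite in direction to the pyrazin-2-yl change. Methylamino in place of pyrazin-2-yl gives a 13-fold lower number from compound 2 to compound 3 (1.10 log units; beyond the scatter), the widest gap among the three compounds. Nothing shown explains these steps.

Open, from the compounds shown here alone, is whether the amide-type hydrogen or the methyl on the nitrogen matters: amino, dimethylamino or methoxy on the same carbonyl carbon would separate these. Also open, going by these compounds, is whether a longer chain, such as ethylamino, keeps the low number.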